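A few compounds are considered here, and "the series" means these few. Any claim that something is new, unique, unknown or untested is made for them only; others in the source may bear on it.

The measured compounds are compound 1 `C(#Cc1nc(-c2ccccc2)nc2c1ncn2Cc1ccccc1)c1ccccc1` with 100%, compound 2 `C(=C/c1[nH]cnc2ncnc1-2)\c1ccco1` with 24%, and compound 3 `C(=C/c1[nH]cnc2ncnc1-2)\c1cccs1` with 50%.

In a functional assay on K562 cells (Homo sapiens) for inhibition, read by thymidine incorporation, with a stated time of 48 h, tested at 10 ug/mL (a higher number here means more inhibition at the concentration tested (going by the name of the read-out), a lower number less inhibition), compound 3 stands second highest of the three: compound 2 gives 24%, lower, and compound 1 gives 100%, higher. Compound 4 `C(=C/c1[nH]cnc2ncnc1-2)\c1ccsc1` differs from compound 3 by thiophen-3-yl in place of thiophen-2-yl on a double-bonded chain carbon bound to a double-bonded chain carbon. Going by the values given here, the only measured step, a number 26 percentage points higher from compound 2 to compound 3 (beyond the scatter), exchanged one five-membered aromatic ring for another at the same place, so it touches the same region, but no step shows how moving the attachment within the thiophene behaves. With compound 3 at 50% as the anchor, a step of a number 5 percentage points lower from compound 3 to compound 4 (within the scatter) is expected, not clearly beyond the scatter. Compound 4 is estimated at 45%, with a range from 25% to 70%.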

Compound 4, a percentage reported as inhibition, at one concentration (the size of the read-out at that concentration, not a potency): 32%
For compound 4 the middle estimate is 13 percentage points above the measured one, within the range that was stated.
By their numbers in this assay, from the lowest: compounds 2 and 4 (each within the scatter of the next); then compound 3; then compound 1.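

Moving the attachment within the thiophene matters in this assay: with the same atoms joined differently, the result is a number 18 percentage points lower from compound 3 to compound 4 (beyond the scatter), so at this place the point of attachment counts, and not only the identity of the ring. The comparison with furan-2-yl gives a number 8 percentage points higher from compound 2 to compound 4 (within the scatter), so the rise seen with thiophen-2-yl does not carry over to thiophen-3-yl. No available evidence accounts for this difference.

The compounds shown leave open how furan-3-yl or a phenyl ring would behave on this double-bonded chain carbon. They also leave open what an amine on the thiophene would do.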